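Chloro-fluoro aryl in place of the sulfonamide aryl

This account rests on a few compounds, and the source may have more. Where it says the series, first, only, none or still open, it means among the compounds named here.

Compound 3 `N#CC1=C(N)Oc2c(c3nc4ccccc4nc3c3ccccc23)C12C(=O)N(Cc1cnnn1-c1ccc(S(N)(=O)=O)cc1)c1ccccc12` is one of three compounds tested in a functional assay on A549 cells (Homo sapiens) for antiproliferative activity, read by MTT assay, with a stated time of 48 h; a higher number here means a weaker inhibitor, a lower number a stronger inhibitor. For compound 3 the assay reports only a limit, > 50000 nM, not a number. Compound 2 `N#CC1=C(N)Oc2c(c3nc4ccccc4nc3c3ccccc23)C12C(=O)N(Cc1cnnn1-c1ccc(F)cc1)c1ccccc12` likewise returns only a limit, > 50000 nM. Compound 1 `Cc1cccc(-n2nncc2CN2C(=O)C3(C(C#N)=C(N)Oc4c3c3nc5ccccc5nc3c3ccccc43)c3ccccc32)c1` gives 39600 nM. The step of an at least 1.2-fold higher number from compound 1 to compound 3 (0.10 log units; that floor lies within the scatter) and the step that the two limits leave unreadable from compound 2 to compound 3 show that the three compounds hardly separate; the limit of > 50000 nM in this assay, at which 2 of the 3 values shown sit, marks where two of them sit. Compound 4 `N#CC1=C(N)Oc2c(c3nc4ccccc4nc3c3ccccc23)C12C(=O)N(Cc1cnnn1-c1ccc(F)c(Cl)c1)c1ccccc12` differs from compound 3 by 3-chloro-4-fluorophenyl in place of 4-sulfamoylphenyl on an aromatic nitrogen. Because compound 2 with its 4-fluorophenyl group sits at the limit of > 50000 nM in this assay, at which 2 of the 3 values shown sit, the step that the limit leaves unreadable from compound 3 to compound 4 is expected to remain within the scatter. Compound 4 is therefore estimated at 60000 nM, with a range from 25000 nM to 150000 nM, and most likely again reported only as a limit.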

Compound 4, half-maximal inhibitory concentration: > 50000 nM
Compound 4: only a limit was reported (the forecaster's own chance of this, stated with the estimate: 65%); the middle value is on the limit's open side.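

Adding chloro to the 4-fluorophenyl group and removing the sulfamoyl group both leave this position without a readable response, so neither a halogen pair nor a sulfonamide on this aryl ring lifts a compound clear of the ceiling of this assay: the limit of > 50000 nM in this assay, at which 3 of the 4 values shown sit.

The steps to compound 4 from compound 2 and from compound 3 cannot be read, since each joins two limits. The remaining comparison gives an at least 1.2-fold higher number from compound 1 to compound 4 (0.10 log units; that floor lies within the scatter), so the 3-methylphenyl and 3-chloro-4-fluorophenyl groups do not separate.

As far as these compounds go, what an amine or a carboxylic acid on this phenyl ring would give stays open. So does the effect of a longer chain on this nitrogen.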